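Removing one hydroxy from the dihydroxyphenyl hydrazone end

A few compounds are considered here, and "the series" means these few. Any claim that something is new, unique, unknown or untested is made for them only; others in the source may bear on it.

Compound 2 `CN(C)CCn1cnnc1-c1cc(Oc2ccc(NC(=O)N/N=C/c3ccc(O)c(O)c3)cc2F)ccn1` holds the lowest number of the three in a functional assay on HT-29 cells (Homo sapiens) for cytotoxicity, read by MTT assay, with a stated time of 72 h (on this read-out lower numbers stand for stronger inhibition and higher numbers for weaker inhibition), giving 1890 nM. Among the measured compounds shown here, compound 3 `Cn1cnnc1-c1cc(Oc2ccc(NC(=O)N/N=C/c3ccccc3)cc2F)ccn1` gives 8790 nM and compound 1 `Cn1ncnc1-c1cc(Oc2ccc(NC(=O)N/N=C/c3ccccc3)cc2F)ccn1` gives 30200 nM; the only single-point step measured, a 3.4-fold lower number from compound 1 to compound 3 (0.54 log units; beyond the scatter), sits on the core and not on the hydrazone end. Compound 4 `CN(C)CCn1cnnc1-c1cc(Oc2ccc(NC(=O)N/N=C/c3cccc(O)c3)cc2F)ccn1` differs from compound 2 by hydrogen in place of hydroxy on an aromatic carbon. For the measured compounds named here, no measured step bears on this change directly; compound 2 and compound 3 differ in two places at once, so their values show only that the dihydroxy-bearing compound carries the lower number. A small rise in the number is therefore expected, within or just beyond the scatter. Compound 4 is estimated at 3500 nM (range 1500 nM to 9000 nM), an expected step of a 1.9-fold higher number from compound 2 to compound 4 (0.27 log units; within the scatter).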

Compound 4, half-maximal inhibitory concentration: 330 nM
Compound 4: middle estimate off by 11-fold (1.03 log units), on the high side; the whole stated range lies above it.
By their numbers in this assay, from the lowest: compound 4; then compound 2; then compound 3; then compound 1.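

Going from 3,4-dihydroxyphenyl to 3-hydroxyphenyl gives a 5.7-fold lower number from compound 2 to compound 4 (0.76 log units; beyond the scatter) in this assay, the first single-point step on the hydrazone end. At this place, ortho to a hydroxy group, the hydroxy is therefore not needed for the lower number, and hydrogen in its place carries a number beyond the scatter from that of the dihydroxy compound. Nothing available explains this direction.

Open, going by these compounds, is whether the remaining hydroxy helps or hurts. Also open, on these data alone, is whether a methoxy or an amine at the vacated place would follow hydrogen or hydroxy.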